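Nitro to chloro on the pendant aryl of compound 1

The source may hold more compounds than are shown below. What is called first, only, known or untested is meant among the compounds shown, and "the series" means these compounds.

The series is followed in a functional assay on Huh-7 cells (Homo sapiens) for inhibition, read by sulforhodamine B assay, with a stated time of 72 h; a higher number here means a weaker inhibitor, a lower number a stronger inhibitor. Compound 1 `COc1ccc2cc(C(C)c3nnc4n3N=C(c3ccc([N+](=O)[O-])cc3)CS4)ccc2c1` gives 14700 nM in this assay, the second highest of the three numbers in hand. Compound 2 `CC(C)Cc1ccc(C(C)c2nnc3n2N=C(c2ccc(C(F)(F)F)cc2)CS3)cc1` gives 8400 nM; its number and that of compound 1 lie within the scatter of each other. Compound 3 `CC(c1ccc(-c2ccccc2)c(F)c1)c1n[nH]c(=S)n1N` gives 43100 nM, and the gap between compound 3 and compound 1 is beyond the scatter. Within the data shown here, no pair of these three compounds differs in a single place, so no measured step is available to anchor the change considered here.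

Compound 4 `COc1ccc2cc(C(C)c3nnc4n3N=C(c3ccc(Cl)cc3)CS4)ccc2c1` is the compound still to be measured. It differs from compound 1 in one place: chloro in place of nitro on an aromatic carbon. The same difference, cut one bond further out, reads 4-nitrophenyl to 4-chlorophenyl. With no measured step of this kind in the set, only a small change is expected, a 1.5-fold lower number from compound 1 to compound 4 (0.17 log units; within the scatter), and it may well not exceed the scatter. Compound 4 is estimated at 10000 nM in this assay, with a range from 3500 nM to 30000 nM.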

Compound 4, half-maximal inhibitory concentration: 5600 nM
Compound 4: middle estimate off by 1.8-fold (0.25 log units), on the high side; low and high end bracket the measured number.
By their numbers in this assay, from the lowest: compounds 4, 2 and 1 (each within the scatter of the next, the first and the last beyond it); then compound 3.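

Among these compounds, the pendant aryl is the first place where a single change can be read: in this assay chloro in place of nitro on the aromatic carbon gives a 2.6-fold lower number from compound 1 to compound 4 (0.42 log units; beyond the scatter) and this step lies beyond the scatter. The number at this position therefore responds to the group carried there, and the nitro group is not required for the activity of compound 1 in this assay. Nothing measured here gives a reason for the step.

Going by these compounds, one step cannot separate the loss of nitro from the arrival of chloro, and it remains open whether a hydrogen, a methoxy group or an amine on this carbon would stand nearer to compound 4 or to compound 1. Whether the same change gives a step of similar size on the core of compound 2 is also unknown.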